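Removing the chloro from compound 3

The source may report more compounds than this note shows. Statements on the series, on what has been measured and on what is new or still open speak of the compounds shown alone.

Of the compounds shown here, three sharing one core have been measured in a functional assay on GBM1 cells (Homo sapiens) for antiproliferative activity, read by WST assay, with a stated time of 72 h (on this read-out higher numbers stand for weaker inhibition and lower numbers for stronger inhibition), so far. There compound 1 `O=C(Nc1ccc(C(F)(F)F)cc1)Nc1cc2ncncc2cc1OCc1cccc(F)c1` gives 3800 nM and compound 2 `O=C(Nc1ccccc1F)Nc1cc2ncncc2cc1OCc1ccccc1` gives 6100 nM in the same test. Compound 3 `O=C(Nc1ccc(C(F)(F)F)cc1)Nc1cc2ncncc2cc1OCc1cccc(Cl)c1` gives 3400 nM and lies within the scatter of both, so its number marks no real lead over either.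

Compound 4 `O=C(Nc1ccc(C(F)(F)F)cc1)Nc1cc2ncncc2cc1OCc1ccccc1` turns the 3-chlorobenzyl of compound 3 into benzyl, with hydrogen in place of chloro on an aromatic carbon.

Going by the values given here, the one measured step on this group is a 1.1-fold lower number from compound 1 to compound 3 (0.05 log units; within the scatter) and it stays within the scatter. Among the compounds with values here, that step swaps one halogen for another, and no measured pair shows a halogen removed on its own. Compound 2 also carries benzyloxy but differs elsewhere, and its 6100 nM stays within the scatter of compound 3 as well.

No step beyond the scatter is therefore expected in this assay, and no firm direction can be given. The estimated change, a 1.2-fold higher number from compound 3 to compound 4 (0.09 log units; within the scatter), is expected to be small. For compound 4 the expected value is 4200 nM, with an estimated range from 2000 nM to 8000 nM.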

Compound 4, half-maximal inhibitory concentration: 5700 nM
For compound 4 the middle estimate is 1.4-fold (0.13 log units) below the measured one; the measured number falls inside the stated range.
By their numbers in this assay, from the lowest: compounds 3, 1, 4 and 2 (each within the scatter of the next).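

Compound 4 supplies the first pairs in which a halogen on this aromatic carbon is removed outright rather than swapped for another: in this assay hydrogen in place of chloro gives a 1.7-fold higher number from compound 3 to compound 4 (0.22 log units; within the scatter) and hydrogen in place of fluoro gives a 1.5-fold higher number from compound 1 to compound 4 (0.18 log units; within the scatter) and both steps stay within the scatter, so neither halogen is shown to matter at this place. Going by these compounds alone, compound 4 also gives the first one-place comparison at the other end of the molecule, where 4-(trifluoromethyl)phenyl in place of 2-fluorophenyl on an amide-type nitrogen gives a 1.1-fold lower number from compound 2 to compound 4 (0.03 log units; within the scatter) and this step too stays within the scatter, so no change seen so far separates these compounds. Nothing measured here offers an explanation for these numbers.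

The compounds shown leave open whether a group of another kind at this place, such as methoxy, an amine or a carboxylic acid, would move the number beyond the scatter. From the compounds shown here alone, it also remains open whether a longer chain in place of benzyloxy, or a pyridine in place of the 4-(trifluoromethyl)phenyl, would separate any compound from this group.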